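A few compounds are considered here, and "the series" means these few. Any claim that something is new, unique, unknown or untested is made for them only; others in the source may bear on it.

In a functional assay (Homo sapiens) (on this read-out lower numbers stand for stronger inhibition and higher numbers for weaker inhibition), two compounds have been measured so far. Compound 1 (`Cc1cnc(-c2cccc(C(F)(F)F)c2)n2nc(N)nc12`) gives 5600 nM, and compound 2 (`CC(=O)Nc1nc2c(C)cnc(-c3cccc([N+](=O)[O-])c3)n2n1`) gives 11000 nM. These two values lie within the usual scatter of each other, so compound 2 cannot be separated from compound 1 on these numbers, and both sit at weak inhibition in absolute terms.

The next compound to be tested is compound 3 (`Cc1cnc(-c2cccc([N+](=O)[O-])c2)n2nc(N)nc12`). It differs from compound 2 in a single place, with hydrogen in place of acetyl on a nitrogen on an aromatic ring, so that acetamido becomes amino: hydrogen in place of acetyl on a nitrogen on an aromatic ring.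

Among the compounds with values here, no measured pair isolates this change, so the data offer no direct precedent for its size, and the expectation is a cautious one. A modest shift toward stronger inhibition in this assay is expected, though a result within the scatter would not be surprising. The expected change is a 2.4-fold lower number from compound 2 to compound 3 (0.39 log units; beyond the scatter). The value of compound 3 is estimated at 4500 nM, with an expected range from 1200 nM to 14000 nM.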

Compound 3, half-maximal inhibitory concentration: 8700 nM
For compound 3 the middle estimate is 1.9-fold (0.29 log units) below the measured one; the range from low to high includes it.
By their numbers in this assay, from the lowest: compounds 1, 3 and 2 (each within the scatter of the next).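

In this assay the first step, hydrogen in place of acetyl on a nitrogen on an aromatic ring, reads a 1.3-fold lower number from compound 2 to compound 3 (0.10 log units; within the scatter) and so stays within the scatter: on these numbers, acetamido and amino at this position cannot be told apart. Compound 3 also links compound 1 to this series through a second single change, nitro in place of trifluoromethyl on an aromatic carbon, which reads a 1.6-fold higher number from compound 1 to compound 3 (0.19 log units; within the scatter) and also stays within the scatter, so neither of the two changes separates its pair. Nothing measured here offers an account of either result.

From the compounds shown here alone, whether a different group on that nitrogen, such as a methyl group or a longer acyl chain, would move the number beyond the scatter remains open, as does the effect of a nitrile or a carboxylic acid on the aromatic carbon that carries nitro in compound 3. All three compounds sit at weak inhibition, so these compounds do not show whether any change at either place can reach much stronger inhibition.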